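Morpholine urea in place of tert-butyl urea on a proline amide

The source may hold more compounds than are shown below. What is called first, only, known or untested is meant among the compounds shown, and "the series" means these compounds.

Compound 1: `CC(=O)N1CCC[C@H]1C(=O)N1CCC(NS(=O)(=O)c2cc(S(=O)(=O)c3ccccc3)ccc2C(F)(F)F)CC1`; in an assay on isolated protein for binding affinity to secreted frizzled-related protein 1 (Homo sapiens), read by fluorescence (a higher number here means a weaker inhibitor, a lower number a stronger inhibitor), compound 1 gives 160 nM.
Compound 2: `CC(C)(C)NC(=O)N1CCC[C@H]1C(=O)N1CCC(NS(=O)(=O)c2cc(S(=O)(=O)c3ccccc3)ccc2C(F)(F)F)CC1`; in this assay compound 2 gives 20 nM.

Compound 2 has the lowest of the two numbers, set apart from compound 1 by an 8.0-fold lower number from compound 1 to compound 2 (0.90 log units; beyond the scatter). Compound 3, `O=C([C@@H]1CCCN1C(=O)N1CCOCC1)N1CCC(NS(=O)(=O)c2cc(S(=O)(=O)c3ccccc3)ccc2C(F)(F)F)CC1`, differs from compound 2 by morpholin-4-yl in place of (tert-butyl)amino on a carbonyl carbon. Among the measured compounds shown here, the one measured step at this carbonyl carbon, an 8.0-fold lower number from compound 1 to compound 2 (0.90 log units; beyond the scatter), shows that this position moves the number by a modest amount, but no measured pair shows a morpholine here. Compound 3 is therefore expected to give a number somewhat higher than compound 2, estimated at 50 nM, with a range from 15 nM to 170 nM. That estimate means a 2.5-fold higher number from compound 2 to compound 3 (0.40 log units; beyond the scatter).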

Compound 3, half-maximal inhibitory concentration: 40 nM
Compound 3: the middle estimate sits 1.3-fold (0.10 log units) above what was measured, within the range that was stated.
By their numbers in this assay, from the lowest: compounds 2 and 3 (each within the scatter of the next); then compound 1.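

With a 2.0-fold higher number from compound 2 to compound 3 (0.30 log units; within the scatter) in this assay the position tolerates morpholin-4-yl about as well as (tert-butyl)amino, so a ring without a hydrogen-bond donor serves here as well as the open group that carries one. Compared with methyl, morpholin-4-yl gives a 4.0-fold lower number from compound 1 to compound 3 (0.60 log units; beyond the scatter) and is thus a second group that stands apart from methyl on this carbonyl carbon. Nothing available explains why these two groups match. Going by these compounds, whether a piperidine, a pyrrolidine or a dimethylamino group on this carbonyl carbon would give a similar number remains open.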